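This account rests on a few compounds, and the source may have more. Where it says the series, first, only, none or still open, it means among the compounds named here.

Compound 1, with the structure `CC1=CC[C@H](C(C)C)c2cc(C)c(OC(=O)c3ccc(C)cc3)cc21`, carries a 4-methylphenyl ester on a shared core. In a functional assay on K562 cells (Homo sapiens) for antiproliferative activity, read by sulforhodamine B assay, with a stated time of 48 h, tested at 50 uM (a higher number here means more inhibition at the concentration tested (going by the name of the read-out), a lower number less inhibition), compound 1 gives 100%. Compound 2, `CC1=CC[C@H](C(C)C)c2cc(C)c(OC(=O)c3ccc([N+](=O)[O-])cc3)cc21`, differs by one change, (nitro in place of methyl on an aromatic carbon), and in this assay compound 2 gives 89%; the step of a number 11 percentage points lower from compound 1 to compound 2 (beyond the scatter) is a modest fall that is beyond the scatter. Compound 3, `CC1=CC[C@H](C(C)C)c2cc(C)c(OC(=O)c3cccc(C)c3)cc21`, has the same atoms as compound 1 joined differently: 3-methylphenyl in place of 4-methylphenyl on a carbonyl carbon. In this assay compound 3 was recorded as "not active" (no number reported), with no number given. Compound 4, `CC1=CC[C@H](C(C)C)c2cc(C)c(OC(=O)c3cccc([N+](=O)[O-])c3)cc21`, has not yet been measured; it differs from compound 3 by nitro in place of methyl on an aromatic carbon. Within the data shown here, this is the same kind of change as the one from compound 1 to compound 2, but not the same: there the nitro sits para to a large group, here it sits meta to a large group. Among the measured compounds shown here, the only measured example of nitro in place of methyl, the step of a number 11 percentage points lower from compound 1 to compound 2 (beyond the scatter), lowered the inhibition number, and it started from a high number, whereas compound 3 was reported as not active. Nothing in these data points to the nitro group restoring what the 3-methylphenyl ester lost. Compound 4 is therefore expected to sit low in this assay, around 12%, with a plausible range from 0% to 40%, and it may well again be reported only as not active.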

Compound 4, a percentage reported as inhibition, at one concentration (the size of the read-out at that concentration, not a potency): 15.9%
Beside the measured number, compound 4's estimate is 3.9 percentage points below it, within the range that was stated.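

Among these compounds, replacing 4-nitrophenyl with 3-nitrophenyl in this assay gives a number 73.1 percentage points lower from compound 2 to compound 4 (beyond the scatter), and replacing 4-methylphenyl with 3-nitrophenyl gives a number 84.1 percentage points lower from compound 1 to compound 4 (beyond the scatter), so in these four compounds high inhibition is seen only with the 4-methylphenyl and 4-nitrophenyl esters. Nitro in place of methyl therefore keeps inhibition high on the 4-methylphenyl ester, but on the 3-methylphenyl ester it does not bring inhibition up to the level of compound 2, and the size of the change there cannot be read, since compound 3 has no number to measure it from; whether the change carries over with the same effect thus stays unknown. The data given offer no measurement that explains why the two kinds of ester differ.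

With only methyl and nitro shown, it remains open whether the sharp difference between the 4-substituted and 3-substituted esters holds for other groups, such as an amine, a carboxylic acid or a longer chain in the same place. A single test concentration also leaves open how potent any of these compounds is, and whether the low readings would look different across a range of concentrations.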